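Acetoxy for methoxycarbonyl on the side chain

The source may hold more compounds than are shown below. What is called first, only, known or untested is meant among the compounds shown, and "the series" means these compounds.

Measured compounds:
compound 1 `N#C/C(=C\c1cccc(Br)n1)C(=O)N[C@@H](CO)c1ccccc1`, 3900 nM
compound 2 `CC[C@H](NC(=O)/C(C#N)=C/c1cccc(Br)n1)c1ccccc1`, 1700 nM
compound 3 `COC(=O)C[C@H](NC(=O)/C(C#N)=C/c1cccc(Br)n1)c1ccccc1`, "not determined" (no result reported)

Within the data shown here, in a functional assay on OCI-My4 cells (Homo sapiens) for antiproliferative activity, read by MTT assay, with a stated time of 72 h (on this read-out higher numbers stand for weaker inhibition and lower numbers for stronger inhibition), compound 1 gives 3900 nM and compound 2 gives 1700 nM; the only measured step, a 2.3-fold lower number from compound 1 to compound 2 (0.36 log units; beyond the scatter), is modest. For compound 3 the result in this read-out is "not determined" (no result reported), so its place among these compounds is unknown; the nearest points are compound 1 and compound 2.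

Compound 4 `CC(=O)OC[C@H](NC(=O)/C(C#N)=C/c1cccc(Br)n1)c1ccccc1` differs from compound 3 in one place: acetoxy in place of methoxycarbonyl on a saturated chain carbon, two bonds along the chain from an amide-type nitrogen and an aromatic carbon. Among the measured compounds shown here, none of the measured steps touches this exchange, and compound 3 itself lacks a value, so there is no step to lean on. The chain carbon that carries the change is the same one where compound 1 bears hydroxy and compound 2 bears methyl, and across those two compounds the numbers stay close to each other. The account therefore expects compound 4 to land in that same region, with wide uncertainty, at an estimated 2500 nM in this assay, between 800 nM and 8000 nM.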

Compound 4, half-maximal inhibitory concentration: 2900 nM
Beside the measured number, compound 4's estimate is 1.2-fold (0.06 log units) below it; low and high end bracket the measured number.
By their numbers in this assay, from the lowest: compounds 2, 4 and 1 (each within the scatter of the next, the first and the last beyond it).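

In this assay the exchange of methoxycarbonyl for acetoxy cannot itself be read, since compound 3 has no result. What compound 4 adds is a third group on the saturated chain carbon, two bonds along the chain from an amide-type nitrogen and an aromatic carbon: a 1.7-fold higher number from compound 2 to compound 4 (0.23 log units; within the scatter) and a 1.3-fold lower number from compound 1 to compound 4 (0.13 log units; within the scatter) are both within the scatter, so acetoxy cannot be told apart from methyl here, and acetylating the hydroxy of compound 1 leaves no readable change. No measurement shown offers an explanation for this result.

Where compound 3 stands among these compounds remains open. So does whether a carboxylic acid, an amine or a longer chain at this position would stay in the same range.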